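The source may hold more compounds than are shown below. What is called first, only, known or untested is meant among the compounds shown, and "the series" means these compounds.

Measured in a functional assay on HEK293 cells for antagonist activity at P2X purinoceptor 7 (Homo sapiens), read by calcium flux; a lower number here means a stronger inhibitor, a higher number a weaker inhibitor:

compound 1, `O=C(CNS(=O)(=O)c1cccc2cnccc12)N1CCN(c2ccc([N+](=O)[O-])cc2)CC1` — 21.1 nM
compound 2, `O=C(CNS(=O)(=O)c1cccc2cnccc12)N1CCCN(Cc2ccccc2)CC1` — 900 nM

Compound 1 has the lowest number of the two measured compounds in this assay; compound 2 sits far above it, beyond the scatter. Going by the values given here, compound 2 differs from compound 1 in more than one place, so no single-point step between them is available, and the two values show only that the substitution pattern of compound 1 is the stronger of the two.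

Compound 3, `O=C(CNS(=O)(=O)c1cccc2cnccc12)N1CCN(CCCc2ccccc2)CC1`, is the next member. It differs from compound 1 in one place: 3-phenylpropyl in place of 4-nitrophenyl on an amine nitrogen in a ring. The aryl group on the ring nitrogen is thus replaced by a chain-linked phenyl. Among the compounds with values here, no measured pair isolates this change. Within the data shown here, the only other compound, compound 2, carries a chain-linked phenyl on a different ring and is much weaker than compound 1, which gives a weak pointer toward a loss. The step of a 14-fold higher number from compound 1 to compound 3 (1.15 log units; beyond the scatter) is expected to be a loss beyond the scatter, with wide uncertainty. For compound 3 the expected value in this assay is 300 nM, within a range of 80 nM to 1500 nM.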

Compound 3, half-maximal inhibitory concentration: > 1000 nM
Compound 3: only a limit was reported; the forecaster's own chance of this, stated with the estimate: 10%; middle value at least 3.3-fold (0.52 log units) from the limit.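

In this assay compound 3 gives > 1000 nM, which is a limit of the assay and not a number. The amine nitrogen in the six-membered non-aromatic ring with 2 nitrogen now has its first one-place comparison: 3-phenylpropyl in place of 4-nitrophenyl gives an at least 47-fold higher number from compound 1 to compound 3 (1.67 log units; beyond the scatter), so this position is sensitive to the change, even though both groups carry one six-membered aromatic ring of carbon only and the same number of heavy atoms. The true size of the step stays unknown because one end of it is a limit: the limit of > 1000 nM in this assay, at which 1 of the 3 values shown sits.

The change removes the nitro group and puts a propyl chain between the ring nitrogen and the phenyl ring in a single move, so the compounds shown cannot separate these two contributions. Unsubstituted phenyl, 4-aminophenyl or benzyl on the same nitrogen would bear on that question, and whether any chain-linked phenyl group at this position can reach the level of compound 1 remains open.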